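This account rests on a few compounds, and the source may have more. Where it says the series, first, only, none or still open, it means among the compounds named here.

Measured so far in a functional assay on CCRF-CEM cells (Homo sapiens) for cytotoxicity, with a stated time of 72 h; a lower number here means a stronger inhibitor, a higher number a weaker inhibitor:
- compound 1 `O=C1CCCC/C1=C\c1ccccc1[N+](=O)[O-]`: 36400 nM
- compound 2 `Cc1ccc(/C=C2\CCC/C(=C\c3ccc([N+](=O)[O-])cc3)C2=O)cc1`: 8530 nM
- compound 3 `O=C1/C(=C/c2ccc(F)cc2)CCC/C1=C\c1cccc([N+](=O)[O-])c1`: 5050 nM

Compound 2 sits in the middle of the three numbers. Compound 1 gives a higher number in this assay, a gap beyond the usual scatter, while the number for compound 3 lies within the scatter of compound 2, so the two cannot be ordered.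

Compound 4 `O=C1/C(=C/c2ccc(Cl)cc2)CCC/C1=C\c1ccc([N+](=O)[O-])cc1` differs from compound 2 in one place: chloro in place of methyl on an aromatic carbon, para to a large group. Among the compounds with values here, no pair of measured compounds shows this change, so its size is not known from the series. The expectation is a step of a 1.2-fold lower number from compound 2 to compound 4 (0.09 log units; within the scatter), within the scatter, with no firm direction. Compound 4 is therefore estimated at 7000 nM, in the range 3000 nM to 17000 nM.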

Compound 4, half-maximal inhibitory concentration: 8180 nM
Compound 4: middle estimate off by 1.2-fold (0.07 log units), on the low side; the measured number falls inside the stated range.
By their numbers in this assay, from the lowest: compounds 3, 4 and 2 (each within the scatter of the next); then compound 1.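

In this assay, within the data shown here, the change from 4-methylphenyl to 4-chlorophenyl gives the first step that can be read, a 1.0-fold lower number from compound 2 to compound 4 (0.02 log units; within the scatter) and so chloro and methyl cannot be told apart on this aromatic carbon, para to a large group. The earlier compounds shown here offered no pair differing in one place. No supporting data speak to why the two groups read alike.

Going by these compounds, whether an amine, a carboxylic acid or a methoxy group on this carbon would move the number beyond the scatter stays open. So does whether the chloro and methyl match holds with the nitro group placed elsewhere on the other ring.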